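From methyl to 2-fluorophenyl on the sulfonyl sulfur

A few compounds are considered here, and "the series" means these few. Any claim that something is new, unique, unknown or untested is made for them only; others in the source may bear on it.

Measured in an ADME assay on HEK293 cells (Homo sapiens) for cytotoxicity, read by resazurin assay, with a stated time of 48 h; on this read-out higher numbers stand for lower toxicity in this test and lower numbers for higher toxicity in this test:
- Compound 1 `O=S(=O)(Nc1ccc(-c2nc3ccccc3o2)cc1)c1cccc(Cl)c1`: > 100000 nM (a limit)
- Compound 2 `CS(=O)(=O)Nc1ccc(-c2nc3ccccc3o2)cc1`: > 100000 nM (a limit)

Compound 2 has only a limit, > 100000 nM, and no exact number. Compound 3 `O=S(=O)(Nc1ccc(-c2nc3ccccc3o2)cc1)c1ccccc1F` puts 2-fluorophenyl in place of methyl on the sulfonyl sulfur: 2-fluorophenyl in place of methyl on a sulfonyl sulfur. Among the measured compounds shown here, the one measured step at this sulfur is a step that the two limits leave unreadable from compound 1 to compound 2, so it offers no size to go by. All that is known is the limit of > 100000 nM in this assay, at which 2 of the 2 values shown sit. Compound 1, which carries 3-chlorophenyl there, also has only a limit, > 100000 nM. In this assay, no change beyond the scatter is expected, so the expected step that the limit leaves unreadable from compound 2 to compound 3 is small. The estimated value for compound 3 is 120000 nM, with an expected range from 50000 nM to 300000 nM.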

Compound 3, half-maximal cytotoxic concentration: > 100000 nM
Compound 3: a limit, no number (the forecaster's own chance of this, stated with the estimate: 80%); the middle value is on the limit's open side.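

No step among compound 1, compound 2 and compound 3 can be read in this assay, because each result is a limit and not a number: the limit of > 100000 nM in this assay, at which 3 of the 3 values shown sit.

Going by these compounds, whether methyl, 3-chlorophenyl and 2-fluorophenyl on the sulfonyl sulfur differ at all in this read-out remains open.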